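This account rests on a few compounds, and the source may have more. Where it says the series, first, only, none or still open, it means among the compounds named here.

Compound 1 `COc1cccc(OC)c1C(=O)Nc1c[nH]nc1C(=O)NN1CCOCC1` and compound 2 `COc1cccc(OC)c1C(=O)Nc1c[nH]nc1C(=O)NC1CCCCCC1` share a core and differ only at the amide-type nitrogen. In an ADME assay on MRC5 cells (Homo sapiens) for inhibition, with a stated time of 72 h (on this read-out higher numbers stand for an effect only at larger amounts of compound and lower numbers for an effect already at smaller amounts), compound 1 gives > 50000 nM, which is a limit of the assay rather than a number (the limit of > 50000 nM in this assay, at which 1 of the 2 values shown sits). In this assay, going by the values given here, compound 2 gives 42000 nM, the only number recorded in this set. Among the compounds with values here, the one further value recorded is the one just mentioned for compound 1, which is a limit of the assay. Within the data shown here, the single step recorded, an at least 1.1-fold lower number from compound 1 to compound 2 (0.07 log units; that floor lies within the scatter), therefore places compound 2 at the upper edge of what this assay can measure.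

Compound 3 `COC(=O)c1n[nH]cc1NC(=O)c1c(OC)cccc1OC` has not been measured. It differs from compound 2 by methoxy in place of cycloheptylamino on a carbonyl carbon. Among the measured compounds shown here, no measured step concerns this change; the only step recorded, from a morpholin-4-yl to a cycloheptyl group, stayed within the scatter, and it offers no direction for a change on the carbonyl carbon. The expectation is thus a step from compound 2 to compound 3 of no size beyond the scatter, a 1.1-fold higher number from compound 2 to compound 3 (0.03 log units; within the scatter), with a real chance that this assay returns only a limit. For compound 3 the estimated value in this assay is 45000 nM, expected to lie between 18000 nM and 100000 nM.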

Compound 3, half-maximal effective concentration: > 50000 nM
Compound 3 ended at the assay's limit (the forecaster's own chance of this, stated with the estimate: 50%); at least 1.1-fold (0.04 log units) between middle value and limit.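

Going by these compounds alone, putting methoxy in place of cycloheptylamino on a carbonyl carbon, a change the earlier compounds did not cover, gives an at least 1.1-fold higher number from compound 2 to compound 3 (0.07 log units; that floor lies within the scatter) in this assay. That floor is all the result provides, so the exchange of this group for a much smaller one, with no ring and no hydrogen-bond donor, shows no change beyond the scatter and no direction can be assigned to it. Compound 3, like compound 1, gives a limit of the assay and not a number, which leaves compound 2 as the only compound with a number: the limit of > 50000 nM in this assay, at which 2 of the 3 values shown sit.

The step between compound 1 and compound 3 cannot be read, as both values are limits, so the morpholin-4-ylamino and methoxy groups cannot be ordered. The compounds shown leave open whether a carboxylic acid, a cyclopentylamino group or a longer chain such as hexylamino on this carbonyl carbon would give a number in this assay clearly different from that of compound 2, and thus whether this position affects the read-out at all.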